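Desulfonylation at the phenol oxygen of compound 1

The source may report more compounds than this note shows. Statements on the series, on what has been measured and on what is new or still open speak of the compounds shown alone.

Compound 1 `C=C1C[C@]23C[C@@]1(O)CC[C@H]2c1ccc(OS(=O)(=O)c2ccc(C)cc2)c(C)c1[C@@H]3Cn1cc(-c2ccc(Cl)cc2)nn1` is measured only in a functional assay on MCF7 cells (Homo sapiens) for cytotoxicity, read by MTT assay, with a stated time of 4 days; on this read-out higher numbers stand for weaker inhibition and lower numbers for stronger inhibition. In this assay compound 1 gives > 20000 nM, which is a limit of the assay and not a number. Compound 2 `C=C1C[C@]23C[C@@]1(O)CC[C@H]2c1ccc(OS(=O)(=O)c2ccc(C)cc2)c(C)c1[C@@H]3Cn1cc(-c2ccc(OC)cc2)nn1` carries methoxy in place of chloro on an aromatic carbon; in this assay compound 2 gives > 20000 nM, also a limit. Compound 3 `C=C1C[C@]23C[C@@]1(O)CC[C@H]2c1ccc(OS(=O)(=O)c2ccc(C)cc2)c(C)c1[C@@H]3Cn1cc(-c2ccc(C(F)(F)F)cc2)nn1` carries trifluoromethyl in place of chloro on an aromatic carbon; in this assay compound 3 gives > 20000 nM, again a limit. The three steps among them, a step that the two limits leave unreadable from compound 1 to compound 2, a step that the two limits leave unreadable from compound 1 to compound 3 and a step that the two limits leave unreadable from compound 2 to compound 3, are therefore not readable, as the limit of > 20000 nM in this assay, at which 3 of the 3 values shown sit, records. For the measured compounds named here, compound 1 thus stands at the limit, and no measured compound gives a number in this assay.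

Compound 4 `C=C1C[C@]23C[C@@]1(O)CC[C@H]2c1ccc(O)c(C)c1[C@@H]3Cn1cc(-c2ccc(Cl)cc2)nn1` differs from compound 1 by hydrogen in place of (4-methylphenyl)sulfonyl on an oxygen on an aromatic ring. Going by the values given here, none of the measured steps touches this oxygen; all three vary the aryl on the triazole, and all leave the value at the limit. Among the compounds with values here, there is no measured step from which the size or direction of the change in this assay can be read. Compound 4 is therefore expected near the limit, with wide uncertainty, at an estimated 15000 nM within 3000 nM to 40000 nM. Within the data shown here, the expected step of an at least 1.3-fold lower number from compound 1 to compound 4 (0.12 log units; that floor lies within the scatter) is an estimate that no measured pair anchors.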

Compound 4, half-maximal inhibitory concentration: > 20000 nM
Compound 4 was reported as a limit; the forecaster's own chance of this, stated with the estimate: 55%; at least 1.3-fold (0.12 log units) between middle value and limit.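

Compound 4 gives > 20000 nM in this assay as a limit and not a number. No step from compound 1 to compound 4 can be read, because both values are limits: the limit of > 20000 nM in this assay, at which 4 of the 4 values shown sit.

The compounds shown leave open whether hydrogen in place of (4-methylphenyl)sulfonyl, or any change of the aryl on the triazole, alters the read-out in this assay at all.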